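This account rests on a few compounds, and the source may have more. Where it says the series, first, only, none or still open, it means among the compounds named here.

Measured so far in a physicochemical assay for pharmacokinetics; a higher number here means that the compound lasts longer, a lower number that the compound disappears faster:
- compound 1 `O=C(NCc1ccccc1Br)N1C(=O)c2ccccc2S1(=O)=O`: > 166 h (a limit)
- compound 2 `O=C(NCc1cccc(Br)c1)N1C(=O)c2ccccc2S1(=O)=O`: > 166 h (a limit)

Compound 2 stands at the limit of > 166 h in this assay, at which 2 of the 2 values shown sit, and is known only as a limit. Compound 3 `O=C(NCc1ccccc1Cl)N1C(=O)c2ccccc2S1(=O)=O` carries 2-chlorophenyl in place of 3-bromophenyl on a saturated chain carbon bound to an amide-type nitrogen. Going by the values given here, the one measured step bearing on this is a step that the two limits leave unreadable from compound 1 to compound 2 and it gives no size to carry over. Compound 1 holds 2-bromophenyl, the nearest group to 2-chlorophenyl in the series, and its > 166 h is a limit. On that basis, no step beyond the scatter is expected in this assay and no direction can be assigned. The expected change is a step that the limit leaves unreadable from compound 2 to compound 3 as an estimate only. Compound 3 is expected at 220 h with an estimated range from 130 h to 400 h and a report as a limit alone is likely.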

Compound 3, half-life: > 166 h
Compound 3 gave a limit, no number; the forecaster's own chance of this, stated with the estimate: 85%; the middle value is on the limit's open side.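

Compound 3 joins compound 1 and compound 2 as a limit in this assay, so no step among the three can be read: the limit of > 166 h in this assay, at which 3 of the 3 values shown sit.

The compounds shown leave open how long each one actually lasts, and whether 2-bromophenyl, 3-bromophenyl and 2-chlorophenyl differ in half-life at all.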